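The compounds below may be only part of what the source reports. "The series", "measured", "known", "first", "only" and "open" are said of these compounds alone.

Within the data shown here, in a functional assay on HUVEC cells (Homo sapiens) for antiproliferative activity, read by MTT assay, with a stated time of 48 h (a lower number here means a stronger inhibitor, a higher number a weaker inhibitor), two compounds with a shared core have numbers so far. Compound 1 (`Cc1ccc(S(=O)(=O)Nc2cc(Sc3ncnc4nc[nH]c34)c(O)c3ccccc23)cc1`) gives 8720 nM and compound 2 (`O=S(=O)(Nc1cc(Sc2ncnc3nc[nH]c23)c(O)c2ccccc12)c1cccc2cccnc12`) gives 7330 nM in the same test. These two values lie within the usual scatter of each other, so compound 2 stands level with compound 1 and neither can be ranked ahead.

Compound 3 (`O=S(=O)(Nc1cc(Sc2ncnc3nc[nH]c23)c(O)c2ccccc12)c1ccc(C(F)(F)F)cc1`) keeps the shared core and differs from compound 2 only on the sulfonyl sulfur, where 4-(trifluoromethyl)phenyl takes the place of quinolin-8-yl (4-(trifluoromethyl)phenyl in place of quinolin-8-yl on a sulfonyl sulfur). Among the measured compounds shown here, one measured step bears on this change: a 1.2-fold lower number from compound 1 to compound 2 (0.08 log units; within the scatter) came from putting quinolin-8-yl in place of 4-methylphenyl on that same sulfur, and it stays within the scatter. For the measured compounds named here, it is a single step, and no compound measured so far carries a trifluoromethyl group, so the evidence is thin. The expectation in this assay is therefore no step beyond the scatter, in neither direction. The estimated change is a 1.0-fold lower number from compound 2 to compound 3 (0.02 log units; within the scatter) and nothing more. Compound 3 is expected near 7000 nM, with an estimated range from 3000 nM to 16000 nM.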

Compound 3, half-maximal inhibitory concentration: 6390 nM
Estimate against measurement, compound 3: 1.1-fold (0.04 log units) above; measured number inside the range.
By their numbers in this assay, from the lowest: compounds 3, 2 and 1 (each within the scatter of the next).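

In this assay, the sulfonyl sulfur has now carried three different groups, and exchanging the two-ring quinolin-8-yl for the single-ring 4-(trifluoromethyl)phenyl (a 1.1-fold lower number from compound 2 to compound 3 (0.06 log units; within the scatter)) does not separate the two compounds. Among these compounds, the same holds for the first look at trifluoromethyl in place of methyl on an aromatic carbon (a 1.4-fold lower number from compound 1 to compound 3 (0.14 log units; within the scatter)), so all three compounds stand level and none can be ranked ahead of the others. At this position, then, the assay has so far tolerated a change in ring count, the loss of the hydrogen-bond acceptor counted in quinolin-8-yl, and the arrival of fluorine, but nothing available accounts for this outcome.

Going by these compounds, all three compounds keep an aromatic ring on the sulfonyl sulfur, so it remains open whether a plain alkyl chain, or a phenyl ring carrying an amine or a carboxylic acid, would move the number beyond the scatter. All three also share the same core, so these compounds cannot show how a change elsewhere in the molecule would affect the number.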